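The compounds below may be only part of what the source reports. "The series", "measured", "known", "first", "only" and "open" are said of these compounds alone.

Compound 1 `O=S(=O)(c1ccc(Cl)cc1)n1c(-c2cn(-c3ccccc3)nc2-c2ccc(F)cc2)nc2ccccc21` and compound 2 `O=S(=O)(c1ccc(Br)cc1)n1c(-c2cn(-c3ccccc3)nc2-c2ccc(F)cc2)nc2ccccc21` share a core that differs from the core of compound 3 `O=S(=O)(c1ccc(Cl)cc1)n1c(-c2cn(-c3ccccc3)nc2-c2ccc(C(F)(F)F)cc2)nc2ccccc21` by trifluoromethyl in place of fluoro on an aromatic carbon. In a functional assay on HepG2 cells (Homo sapiens) for antiproliferative activity, read by MTT assay, with a stated time of 24 h (a lower number here means a stronger inhibitor, a higher number a weaker inhibitor), compound 1 gives 4230 nM, compound 2 gives 2550 nM, and compound 3 gives 3930 nM. The step of a 1.7-fold lower number from compound 1 to compound 2 (0.22 log units; within the scatter) is the result of the change (bromo in place of chloro on an aromatic carbon). The step of a 1.1-fold lower number from compound 1 to compound 3 (0.03 log units; within the scatter) accompanies the difference between the two cores. Compound 4 `O=S(=O)(c1ccc(Br)cc1)n1c(-c2cn(-c3ccccc3)nc2-c2ccc(C(F)(F)F)cc2)nc2ccccc21` is not yet measured; it arises from compound 3 by bromo in place of chloro on an aromatic carbon, the same change that turns compound 1 into compound 2. Because the step of a 1.7-fold lower number from compound 1 to compound 2 (0.22 log units; within the scatter) is small, a step of similar size is expected here, namely a 1.6-fold lower number from compound 3 to compound 4 (0.21 log units; within the scatter). Compound 4 is therefore estimated to give 2400 nM in this assay, with a likely range from 1200 nM to 4800 nM.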

Compound 4, half-maximal inhibitory concentration: 2160 nM
Compound 4: the middle estimate sits 1.1-fold (0.05 log units) above what was measured; measured number inside the range.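

In this assay, bromo in place of chloro on the second core gives a 1.8-fold lower number from compound 3 to compound 4 (0.26 log units; within the scatter), and trifluoromethyl in place of fluoro with bromo present gives a 1.2-fold lower number from compound 2 to compound 4 (0.07 log units; within the scatter). The bromo change carries from one core to the other without a difference that can be told apart: the same change on two cores in this assay, a 1.7-fold lower number (0.22 log units; within the scatter) from compound 1 to compound 2 and a 1.8-fold lower number (0.26 log units; within the scatter) from compound 3 to compound 4, 1.1-fold (0.04 log units) apart, within the scatter of two such steps All of these steps lie within the scatter, so the agreement shows only that neither change visibly depends on the other across these four compounds, not that either change has a real effect on the number, and the trifluoromethyl change reads the same way: the same change on two cores in this assay, a 1.1-fold lower number (0.03 log units; within the scatter) from compound 1 to compound 3 and a 1.2-fold lower number (0.07 log units; within the scatter) from compound 2 to compound 4, 1.1-fold (0.04 log units) apart, within the scatter of two such steps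

The compounds shown leave open how an amine or a carboxylic acid in place of bromo would behave. They also leave open whether any change at this place would carry between the cores once its step is large.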